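The compounds below may be only part of what the source reports. "The series", "measured", "known", "first", "only" and "open" are said of these compounds alone.

Working notes on the series. The shared core carries a variable group on a saturated chain carbon bound to a saturated ring carbon. In an ADME assay on HEK293-A cells (Homo sapiens) for cytotoxicity, read by MTT assay, with a stated time of 48 h (a higher number here means a weaker inhibitor, a lower number a stronger inhibitor), compound 1 `O=C1CCC(=O)N1C[C@H]1CN(c2ccc(-n3cc(-c4ccccn4)cn3)c(F)c2)C(=O)O1` gives > 400 ug/mL, which is a limit of the assay and not a number. In this assay compound 2 `COC[C@H]1CN(c2ccc(-n3cc(-c4ccccn4)cn3)c(F)c2)C(=O)O1` likewise gives > 400 ug/mL, again a limit. The step that the two limits leave unreadable from compound 1 to compound 2 therefore cannot be sized because both values sit at the limit described in the limit of > 400 ug/mL in this assay, at which 2 of the 2 values shown sit. On the numbers shown, compound 2 stands only at a limit, with no readable placing relative to compound 1.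

Compound 3 `O=C1O[C@@H](Cn2ccnc2)CN1c1ccc(-n2cc(-c3ccccn3)cn2)c(F)c1` differs from compound 2 by 1H-imidazol-1-yl in place of methoxy on a saturated chain carbon bound to a saturated ring carbon. Among the measured compounds shown here, the one measured step bears on the same position but is unreadable, so it gives no size for the present change in either direction. In this assay compound 3 is expected to give 500 ug/mL, with a range of 200 ug/mL to 1500 ug/mL, most probably reported once more as a limit. The expected step that the limit leaves unreadable from compound 2 to compound 3 is accordingly estimated as no change beyond the scatter.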

Compound 3, half-maximal inhibitory concentration: > 400 ug/mL
Compound 3 was reported as a limit (the forecaster's own chance of this, stated with the estimate: 85%); the middle value is on the limit's open side.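

The steps to compound 3 from compound 1 and from compound 2 cannot be read, because all three compounds give a limit and not a number: the limit of > 400 ug/mL in this assay, at which 3 of the 3 values shown sit.

The compounds shown leave open how far compound 1, compound 2 and compound 3 actually differ in this assay, and whether changing the group on this saturated chain carbon alters the half-maximal inhibitory concentration at all.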